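Swapping a benzyl for a cyclobutyl on the triazole nitrogen

A few compounds are considered here, and "the series" means these few. Any claim that something is new, unique, unknown or untested is made for them only; others in the source may bear on it.

Of the compounds shown here, three sharing one core have been measured in a functional assay on RAW264.7 cells (Mus musculus) for inhibition, read by Griess assay, with stated times of 2 h and 24 h; a lower number here means a stronger inhibitor, a higher number a weaker inhibitor. Compound 1, `COc1ccc([C@@H]2CC(=O)c3c(O)cc(OCc4cn(Cc5cccc(Cl)c5)nn4)cc3O2)cc1O`, gives 18200 nM, the highest of the three numbers. Compound 2, `COc1ccc([C@@H]2CC(=O)c3c(O)cc(OCc4cn(Cc5ccccc5Cl)nn4)cc3O2)cc1O`, gives 6140 nM, and compound 3, `COc1ccc([C@@H]2CC(=O)c3c(O)cc(OCc4cn(Cc5ccc(F)cc5)nn4)cc3O2)cc1O`, gives 15100 nM. Against compound 1 the two steps are a 3.0-fold lower number from compound 1 to compound 2 (0.47 log units; beyond the scatter) and a 1.2-fold lower number from compound 1 to compound 3 (0.08 log units; within the scatter); between the other two stands a 2.5-fold higher number from compound 2 to compound 3 (0.39 log units; beyond the scatter). All three changes only move a halogen around the phenyl ring of the benzyl group.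

Compound 4, `COc1ccc([C@@H]2CC(=O)c3c(O)cc(OCc4cn(C5CCC5)nn4)cc3O2)cc1O`, is not yet measured. It differs from compound 1 as follows: cyclobutyl in place of 3-chlorobenzyl on an aromatic nitrogen. This is a different kind of change from any measured step: the aromatic ring leaves altogether and a small saturated ring takes its place. Within the data shown here, no measured pair speaks to this exchange. The measured steps show that rearranging the halogen shifts the number by at most a modest amount, and compound 3 shows a change that stays within the scatter. Among the measured compounds shown here, with no direct precedent, the expected step in this assay is uncertain in direction, and the range must be wide; the step is estimated as a 1.2-fold higher number from compound 1 to compound 4 (0.08 log units; within the scatter). Compound 4 is therefore expected to give 22000 nM, with a range from 7000 nM to 70000 nM.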

Compound 4, half-maximal inhibitory concentration: 15300 nM
Estimate against measurement, compound 4: 1.4-fold (0.16 log units) above; the range from low to high includes it.
By their numbers in this assay, from the lowest: compound 2; then compounds 3, 4 and 1 (each within the scatter of the next).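

In this assay, the aromatic ring of the benzyl group proves dispensable at this aromatic nitrogen for the level of inhibition seen with two of the three benzyl compounds: cyclobutyl cannot be told apart from 3-chlorobenzyl (a 1.2-fold lower number from compound 1 to compound 4 (0.08 log units; within the scatter)) or from 4-fluorobenzyl (a 1.0-fold higher number from compound 3 to compound 4 (0.01 log units; within the scatter)). Among these compounds, the exception is compound 2, whose 2-chlorobenzyl group remains separated from cyclobutyl (a 2.5-fold higher number from compound 2 to compound 4 (0.40 log units; beyond the scatter)), so only that benzyl compound goes against the picture of a position that tolerates the exchange without a change in the number. The earlier compounds shown here showed that moving or changing the halogen could matter, and compound 4 adds that neither the halogen nor the aromatic ring is required to reach the level of compounds 1 and 3, while the lower number of compound 2 is tied to a 2-chlorobenzyl group that cyclobutyl does not match.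

The compounds shown leave open whether a cyclohexyl ring, a longer alkyl chain, an amine or a carboxylic acid on this aromatic nitrogen would separate from these numbers in either direction. No evidence is available to explain why compound 2 stands apart from the others.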